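A few compounds are considered here, and "the series" means these few. Any claim that something is new, unique, unknown or untested is made for them only; others in the source may bear on it.

Working notes on the series.

Of the compounds shown here, three of the shared core have been measured in a physicochemical assay for solubility, measured as kinetic solubility, at pH 2; a higher number here means a more soluble compound, a lower number a less soluble compound. Compound 1 `C/C(=C1/OC(=O)NC1=O)C(c1ccc(-c2ccc3cccc(F)c3c2)[nH]c1=O)C(C)C` gives 12700 nM in this assay. Compound 2 `CC(C)C(/C=C1\OC(=O)NC1=O)c1cc(Cl)c(-c2ccc3cccc(F)c3c2)[nH]c1=O` gives 3200 nM in this assay, and compound 3 `CCC(CC)C(/C=C1\OC(=O)NC1=O)c1ccc(-c2ccc3cccc(F)c3c2)[nH]c1=O` gives 3680 nM. On these numbers compound 1 stands highest of the three: compound 3 is nearest, with a lower number, a gap that is beyond the scatter, and compound 2 is furthest, with a lower number still, a gap that is also beyond the scatter. For the measured compounds named here, no pair among the measured compounds differs in a single place, so no step between measured compounds can be read directly.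

The unmeasured compound 4 `CC(C)C(CC1NC(=O)NC1=O)c1ccc(-c2ccc3cccc(F)c3c2)[nH]c1=O` is related to compound 1 by one change: a group of 8 heavy atoms (4 carbon, 2 nitrogen, 2 oxygen; one five-membered non-aromatic ring with 2 hetero atoms) in place of a group of 9 heavy atoms (5 carbon, 1 nitrogen, 3 oxygen; one five-membered non-aromatic ring with 2 hetero atoms), on a saturated chain carbon bound to an aromatic carbon and a saturated chain carbon.

Going by the values given here, no measured step supports this change, so the expectation rests on the position of compound 1 alone. The expected step of a 1.6-fold higher number from compound 1 to compound 4 (0.20 log units; within the scatter) is modest and upward, of a size that may not clear the scatter. Compound 4 is estimated in this assay at 20000 nM, with a range from 8000 nM to 50000 nM.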

Compound 4, solubility: 13000 nM
For compound 4 the middle estimate is 1.5-fold (0.19 log units) above the measured one, and the stated range covers the measured number.
By their numbers in this assay, from the lowest: compounds 2 and 3 (each within the scatter of the next); then compounds 1 and 4 (each within the scatter of the next).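

In this assay, for the compounds shown here, the exchange on the saturated chain carbon, with (2,5-dioxoimidazolidin-4-yl)methyl entering, gives a 1.0-fold higher number from compound 1 to compound 4 (0.01 log units; within the scatter) and is the first single-place step that can be read, as the earlier compounds offered no such pair. The group that enters differs from the one that leaves in several counted features at once, with 2 double bonds outside aromatic rings against 3, and 2 hydrogen-bond donors and 2 acceptors against 1 and 3, yet this step stays within the scatter, so at this position the two groups cannot be told apart on this read-out. Nothing measured here accounts for that result.

This one step cannot show which of the counted features matter, or whether any of them would count on a core carrying the chloro group of compound 2 or the longer branched chain of compound 3. Also open, from the compounds shown here alone, is how a group of another kind at the same saturated chain carbon, such as a carboxylic acid or an amine, would read in this assay against these two five-membered rings.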